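Aryl swap on the shared core: outlook for compound 3

The source may report more compounds than this note shows. Statements on the series, on what has been measured and on what is new or still open speak of the compounds shown alone.

compound 1 `COc1ccc(-c2c3ccc4ccccc4c3nc3c2c(C)nc2c4ccccc4ccc32)cc1` — 45900 nM
compound 2 `Cc1nc2c3ccccc3ccc2c2nc3c(ccc4ccccc43)c(-c3ccccc3S)c12` — 3190 nM

In a functional assay on HeLa cells (Homo sapiens) for cytotoxicity, read by MTT assay, with a stated time of 48 h (a lower number here means a stronger inhibitor, a higher number a weaker inhibitor), compound 2 gives 3190 nM, the lowest of the two numbers measured; its nearest neighbour is compound 1, which gives 45900 nM. For the measured compounds named here, the single measured step, a 14-fold lower number from compound 1 to compound 2 (1.16 log units; beyond the scatter), went with 2-sulfanylphenyl in place of 4-methoxyphenyl on an aromatic carbon of the shared core.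

Compound 3 `Cc1ccc(-c2c3ccc4ccccc4c3nc3c2c(C)nc2c4ccccc4ccc32)cc1` differs from compound 2 by 4-methylphenyl in place of 2-sulfanylphenyl on an aromatic carbon. The measured step bears on it in reverse: compound 3, like compound 1, lacks the 2-sulfanylphenyl of compound 2, and compound 1 sits well above compound 2 in this assay. Going by the values given here, a large step upward in number is therefore expected, though the two groups without sulfur are not identical and only one comparison exists. The step expected here is a 9.4-fold higher number from compound 2 to compound 3 (0.97 log units; beyond the scatter), upward in number. Compound 3 is estimated at 30000 nM, with a range of 8000 nM to 100000 nM.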

Compound 3, half-maximal inhibitory concentration: 72200 nM
Compound 3: middle estimate off by 2.4-fold (0.38 log units), on the low side, within the range that was stated.
By their numbers in this assay, from the lowest: compound 2; then compounds 1 and 3 (each within the scatter of the next).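

In this assay, the result gives a 23-fold higher number from compound 2 to compound 3 (1.35 log units; beyond the scatter), so a second aryl group without sulfur, on the aromatic carbon opposite the ring nitrogen, also stands well above compound 2. The low number of compound 2 now holds against two different replacements rather than one. The other new comparison gives a 1.6-fold higher number from compound 1 to compound 3 (0.20 log units; within the scatter), so 4-methoxyphenyl and 4-methylphenyl cannot be told apart at this position in this assay. No measurement at hand accounts for the gap between compound 2 and the two compounds without sulfur.

Compound 2 differs from compound 1 and compound 3 both in carrying sulfur and in where its phenyl group is substituted, so these compounds cannot separate the two. A 2-methylphenyl, 4-sulfanylphenyl or 2-hydroxyphenyl group on the shared core would bear on that question.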